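Swapping Methoxy for Chloro on the Aryl Ring

The compounds below may be only part of what the source reports. "The series", "measured", "known", "first", "only" and "open" are said of these compounds alone.

Of the compounds shown here, three sharing one core have been measured in a functional assay on A549 cells (Homo sapiens) for inhibition, read by MTT assay, with a stated time of 24 h; a higher number here means a weaker inhibitor, a lower number a stronger inhibitor. Compound 1 `Cc1ccccc1-n1cc(CN2C(=O)C[C@@H]3CC[C@@]2(C)C3(C)C)nn1` gives 90 nM, compound 3 `CC1(C)[C@H]2CC[C@]1(C)N(Cc1cn(-c3ccccc3C#N)nn1)C(=O)C2` gives 100 nM, and compound 2 `COc1ccccc1-n1cc(CN2C(=O)C[C@@H]3CC[C@@]2(C)C3(C)C)nn1` gives 350 nM. Compound 2 therefore shows the highest number of the three: the step from it to compound 3 is a 3.5-fold lower number from compound 2 to compound 3 (0.54 log units; beyond the scatter), and the step leading to it from compound 1 is a 3.9-fold higher number from compound 1 to compound 2 (0.59 log units; beyond the scatter). Compounds 1 and 3 sit within the scatter of each other, as the step of a 1.1-fold higher number from compound 1 to compound 3 (0.05 log units; within the scatter) shows.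

The next compound, compound 4 `CC1(C)[C@H]2CC[C@]1(C)N(Cc1cn(-c3ccccc3Cl)nn1)C(=O)C2`, differs from compound 2 in one place: chloro in place of methoxy on an aromatic carbon. For the measured compounds named here, two measured steps bear on this. Cyano entering in place of methoxy gave a 3.5-fold lower number from compound 2 to compound 3 (0.54 log units; beyond the scatter), and methoxy entering in place of methyl gave a 3.9-fold higher number from compound 1 to compound 2 (0.59 log units; beyond the scatter). Both steps point the same way: methoxy at this position goes with the weaker number, while the two other groups tried there gave numbers within the scatter of each other. Because replacing methoxy with cyano gave a 3.5-fold lower number from compound 2 to compound 3 (0.54 log units; beyond the scatter), a step of similar size and in the same direction is expected for chloro, a 3.5-fold lower number from compound 2 to compound 4 (0.54 log units; beyond the scatter). Compound 4 is therefore estimated at about 100 nM, with a likely range from 40 nM to 250 nM.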

Compound 4, half-maximal inhibitory concentration: 70 nM
Compound 4: the middle estimate sits 1.4-fold (0.15 log units) above what was measured; the measured number falls inside the stated range.
By their numbers in this assay, from the lowest: compounds 4, 1 and 3 (each within the scatter of the next); then compound 2.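

With chloro, a third group has now replaced methoxy at this position, on the aromatic carbon ortho to a large group, and the number in this assay again falls beyond the scatter (a 5.0-fold lower number from compound 2 to compound 4 (0.70 log units; beyond the scatter)). Methoxy therefore stands apart from three groups rather than two, so the earlier result does not depend on cyano or methyl alone. Chloro does not separate from those two groups (a 1.4-fold lower number from compound 3 to compound 4 (0.15 log units; within the scatter) and a 1.3-fold lower number from compound 1 to compound 4 (0.11 log units; within the scatter)), so methyl, cyano and chloro cannot be ranked here, and no supporting measurement explains why methoxy stands apart.

The compounds shown leave open how a longer chain such as ethoxy, or an amine or a carboxylic acid, would fare at this same position, and so whether methoxy is a lone exception or part of a wider trend. All four compounds also share one core, which leaves open whether the swap from 2-methoxyphenyl to 2-chlorophenyl would give a similar step on any other core.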